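The source may hold more compounds than are shown below. What is called first, only, known or untested is meant among the compounds shown, and "the series" means these compounds.

Measured so far in a functional assay on HCT-116 cells (Homo sapiens) for cytotoxicity, read by MTT assay, with a stated time of 48 h; a higher number here means a weaker inhibitor, a lower number a stronger inhibitor:

- compound 1 `Nc1ccc(C(=O)/C=C/c2ccc3c(c2)B(O)OC3)cc1`: 26100 nM
- compound 2 `O=C(/C=C/c1ccc2c(c1)B(O)OC2)c1ccccc1F`: 4200 nM
- compound 3 `O=C(/C=C/c1ccc2c(c1)B(O)OC2)c1cccc(F)c1`: 6700 nM

Compound 3 stands second highest of the three numbers in this assay; the nearest is a 1.6-fold higher number from compound 2 to compound 3 (0.20 log units; within the scatter), the furthest a 3.9-fold lower number from compound 1 to compound 3 (0.59 log units; beyond the scatter). The two fluoro compounds therefore sit together, and only the change away from the aminophenyl compound 1 has moved the number beyond the scatter, as a 6.2-fold lower number from compound 1 to compound 2 (0.79 log units; beyond the scatter) also shows.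

Compound 4 `COc1cccc(C(=O)/C=C/c2ccc3c(c2)B(O)OC3)c1` differs from compound 3 by methoxy in place of fluoro on an aromatic carbon. Among the measured compounds shown here, none of the measured steps exchanges one such small substituent for another at this place; the steps from compound 1 swap the whole aryl substituent pattern and are modest in size. For the measured compounds named here, no direct precedent exists for methoxy here, so the step in this assay is expected to be small, most likely within the scatter, with no direction favoured: a 1.0-fold higher number from compound 3 to compound 4 (0.02 log units; within the scatter). Compound 4 is accordingly estimated at 7000 nM, with a range of 2500 nM to 20000 nM.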

Compound 4, half-maximal inhibitory concentration: 5000 nM
Compound 4: middle estimate off by 1.4-fold (0.15 log units), on the high side, and the stated range covers the measured number.
By their numbers in this assay, from the lowest: compounds 2, 4 and 3 (each within the scatter of the next); then compound 1.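

In this assay, methoxy in place of fluoro on an aromatic carbon, meta to a large group, gives a 1.3-fold lower number from compound 3 to compound 4 (0.13 log units; within the scatter). Among the compounds shown here, this is the first step that exchanges the substituent itself at this place, rather than moving a fluoro or replacing the whole aryl substituent pattern, and the entering methoxy, with its hydrogen-bond acceptor, leaves the number within the scatter. No measurement shown explains why this exchange leaves the number within the scatter.

The compounds shown leave open whether an amine, a carboxylic acid or a longer chain such as ethoxy on this same aromatic carbon would also stay within the scatter of compound 3. They also leave open whether methoxy would behave the same way on another carbon of this ring.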